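Shrinking the side chain of compound 3

This account rests on a few compounds, and the source may have more. Where it says the series, first, only, none or still open, it means among the compounds named here.

Measured in a functional assay on DLD-1 cells (Homo sapiens) for inhibition, read by MTT assay, with a stated time of 72 h; a higher number here means a weaker inhibitor, a lower number a stronger inhibitor:
Compound 1 `COc1cc(Oc2cccc(Nc3ccccc3)c2)cc(OC)c1CNCc1ccccc1` gives 5220 nM
Compound 2 `COc1cc(Oc2cccc(Nc3ccccc3)c2)cc(OC)c1CNCc1ccc(C)cc1` gives 6080 nM
Compound 3 `COc1ccc(CCCNCc2c(OC)cc(Oc3cccc(Nc4ccccc4)c3)cc2OC)cc1` gives 2540 nM

Compound 3 has the lowest number of the three, which makes it the strongest inhibitor so far. Compound 4 `COc1cc(Oc2cccc(Nc3ccccc3)c2)cc(OC)c1CN(C)C` carries dimethylamino in place of (3-(4-methoxyphenyl)propyl)amino on a saturated chain carbon bound to an aromatic carbon. Two modest measured steps bear on this change: a 2.1-fold lower number from compound 1 to compound 3 (0.31 log units; beyond the scatter) and a 2.4-fold lower number from compound 2 to compound 3 (0.38 log units; beyond the scatter) and the third, a 1.2-fold higher number from compound 1 to compound 2 (0.07 log units; within the scatter) adds little. Every measured compound keeps an aromatic ring in that side chain, so no measurement shows its loss. A higher number is therefore expected in this assay with an estimated step of a 3.5-fold higher number from compound 3 to compound 4 (0.55 log units; beyond the scatter) (a weaker inhibitor). Compound 4 is estimated at 9000 nM and expected to fall between 3500 nM and 25000 nM on this reasoning.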

Compound 4, half-maximal inhibitory concentration: > 20000 nM
Compound 4 was reported as a limit; the forecaster's own chance of this, stated with the estimate: 15%; middle value at least 2.2-fold (0.34 log units) from the limit.
By their numbers in this assay, from the lowest: compound 3; then compounds 1 and 2 (each within the scatter of the next). At a limit, above all of these: compound 4.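

Compound 4 is reported in this assay only as a limit, > 20000 nM. Swapping the side chain for dimethylamino, which has no ring, gives the largest steps seen at this position: an at least 7.8-fold higher number from compound 3 to compound 4 (0.89 log units; beyond the scatter), an at least 3.2-fold higher number from compound 2 to compound 4 (0.51 log units; beyond the scatter) and an at least 3.8-fold higher number from compound 1 to compound 4 (0.58 log units; beyond the scatter). The aromatic side chains differ only modestly among themselves, whereas this small group falls clearly behind all three.

The change removes the aromatic ring and the hydrogen-bond donor together, so the compounds shown cannot separate the two. Benzyl(methyl)amino, which keeps the ring without the donor, and cyclohexylmethylamino, which keeps the donor without an aromatic ring, remain open.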